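Furan to thiophene swap on two nucleoside cores

The compounds below may be only part of what the source reports. "The series", "measured", "known", "first", "only" and "open" are said of these compounds alone.

Compound 1 `COc1nc(N)nc2c1c(-c1cccs1)cn2[C@@H]1O[C@H](CO)[C@@H](O)[C@H]1O` and compound 2 `COc1nc(N)nc2c1c(-c1ccoc1)cn2[C@@H]1O[C@H](CO)[C@@H](O)[C@H]1O` share one core; compound 3 `CSc1ncnc2c1c(-c1ccoc1)cn2[C@@H]1O[C@H](CO)[C@@H](O)[C@H]1O` is built on another, and the difference between the two cores is not broken down here. Compound 4 `CSc1ncnc2c1c(-c1cccs1)cn2[C@@H]1O[C@H](CO)[C@@H](O)[C@H]1O` is not yet measured.

In a functional assay on K562 cells (Homo sapiens), read by MTT assay, with a stated time of 72 h (on this read-out higher numbers stand for weaker inhibition and lower numbers for stronger inhibition), compound 1 gives > 20000 nM, which is a limit of the assay and not a number. Compound 2 also gives > 20000 nM, again a limit. Among the measured compounds shown here, compound 3 gives 60 nM, the only number among the three. The change thiophen-2-yl in place of furan-3-yl on an aromatic carbon produces a step that the two limits leave unreadable from compound 2 to compound 1; its size cannot be read because the limit of > 20000 nM in this assay, at which 2 of the 3 values shown sit, holds both ends of that pair.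

The change thiophen-2-yl in place of furan-3-yl on an aromatic carbon is the same change made on the core of compound 3. The step of a 1.3-fold higher number from compound 3 to compound 4 (0.12 log units; within the scatter) is expected to be small, resting on compound 3 at 60 nM and on the earlier pair giving no readable size. Compound 4 is expected near 80 nM, between 20 nM and 400 nM.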

Compound 4, half-maximal inhibitory concentration: 11600 nM
For compound 4 the middle estimate is 150-fold (2.16 log units) below the measured one; measured number outside the range, above it.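

On the core of compound 3, thiophen-2-yl in place of furan-3-yl gives, in this assay, a 190-fold higher number from compound 3 to compound 4 (2.29 log units; beyond the scatter), so this change is not neutral on that core. Among the compounds shown here, the same change cannot be read on the other core, because both ends of the step from compound 2 to compound 1 sit at a limit and not at a number: the limit of > 20000 nM in this assay, at which 2 of the 4 values shown sit. Only one readable pair therefore stands, which shows the size of the step on one core and does not show whether that size carries over to another core.

Open, as far as these compounds go, is whether the high number of compound 4 is particular to thiophen-2-yl, or whether phenyl on the same aromatic carbon would read alike. Also open, from the compounds shown here alone, is whether any group there brings the core of compound 2 off the limit.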